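The source may hold more compounds than are shown below. What is called first, only, known or untested is meant among the compounds shown, and "the series" means these compounds.

Compound 1 `CCN(CC)Cc1c(O)c([C@H]2CCN(C)C[C@H]2O)c2oc(C)cc(=O)c2c1O`: 24%
Compound 2 `Cc1cc(=O)c2c(O)c(CN3CCC(Cc4ccccc4)CC3)c(O)c([C@H]3CCN(C)C[C@H]3O)c2o1`: 17%

In a functional assay on MCF7 cells (Homo sapiens) for inhibition, read by MTT assay, with a stated time of 48 h, tested at 10 uM (a higher number here means more inhibition of growth at the concentration tested, a lower number less inhibition of growth), compound 1 gives 24% and compound 2 gives 17% and these two numbers lie within the usual scatter of each other, which is where compound 1 stands on the data so far. As far as these compounds go, compound 3 `Cc1cc(=O)c2c(O)c(CN(C(C)C)C(C)C)c(O)c([C@H]3CCN(C)C[C@H]3O)c2o1` has yet to be measured in this assay as its value is still unknown. Compared with compound 1 it carries diisopropylamino in place of diethylamino on a saturated chain carbon bound to an aromatic carbon and the rest of the structure is the same. For the measured compounds named here, no two measured compounds differ in one place only, so the data hold no direct precedent for this change. With compound 1 at 24% as the starting point, no step beyond the scatter is expected in either direction. The estimated step of a number 4 percentage points lower from compound 1 to compound 3 (within the scatter) stays within the scatter. For compound 3 the estimated value is 20% with an expected range from 6% to 36% in this measurement.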

Compound 3, percent growth inhibition at one concentration: 33%
Compound 3: middle estimate off by 13 percentage points, on the low side; measured number inside the range.
By their numbers in this assay, from the lowest: compounds 2, 1 and 3 (each within the scatter of the next, the first and the last beyond it).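

In this assay, for the compounds shown here, the exchange of diethylamino for diisopropylamino on a saturated chain carbon bound to an aromatic carbon gives the first direct reading of a single change at this position, a step of a number 9 percentage points higher from compound 1 to compound 3 (within the scatter). The shared core therefore keeps its reading within the scatter when this one amine takes the place of the other, so the data show no measurable effect of the exchange at this position. Nothing measured here bears on this result, and the reading stands without an explanation.

As far as these compounds go, it remains open whether a ring amine such as morpholine or pyrrolidine, or a simple primary amine, at the same place would give a step beyond the scatter. From the compounds shown here alone, it also remains open whether a longer chain between the amine and the aromatic carbon would change the reading.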